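A few compounds are considered here, and "the series" means these few. Any claim that something is new, unique, unknown or untested is made for them only; others in the source may bear on it.

Measured so far, in a functional assay on PC-3 cells (Homo sapiens) for cytotoxicity, read by MTT assay, with a stated time of 72 h; a higher number here means a weaker inhibitor, a lower number a stronger inhibitor:
Compound 1 `CCCCCCNc1nc(SCc2ccc(C(F)(F)F)cc2)nc2ccccc12`: 19000 nM
Compound 2 `COc1ccccc1Nc1nc(SCc2ccc(C(F)(F)F)cc2)nc2ccccc12`: 14100 nM

Among the measured compounds shown here, compound 1 carries the higher of these two numbers, but the gap to its only neighbour, a 1.3-fold lower number from compound 1 to compound 2 (0.13 log units; within the scatter), lies within the scatter, so the two cannot really be told apart.

Compound 3 `FC(F)(F)c1ccc(CSc2nc(Nc3cccc(Br)c3)c3ccccc3n2)cc1` has not been measured. It differs from compound 1 in one place: 3-bromophenyl in place of hexyl on a nitrogen on an aromatic ring. For the measured compounds named here, the single measured step that resembles this change, 2-methoxyphenyl in place of hexyl on a nitrogen on an aromatic ring, is a 1.3-fold lower number from compound 1 to compound 2 (0.13 log units; within the scatter): no movement beyond the scatter. Going by the values given here, with only this one comparison to lean on, compound 3 is expected to land close to compound 1, and the expected shift is small, a 1.3-fold lower number from compound 1 to compound 3 (0.10 log units; within the scatter). Compound 3 is therefore estimated at 15000 nM, within a range of 6000 nM to 40000 nM.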

Compound 3, half-maximal inhibitory concentration: 8680 nM
Estimate against measurement, compound 3: 1.7-fold (0.24 log units) above; the measured number falls inside the stated range.
By their numbers in this assay, from the lowest: compounds 3, 2 and 1 (each within the scatter of the next, the first and the last beyond it).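

Among the compounds shown here, at this nitrogen, 3-bromophenyl gives the first step in this assay that goes beyond the scatter (a 2.2-fold lower number from compound 1 to compound 3 (0.34 log units; beyond the scatter)), so swapping the hexyl chain for an aromatic ring can shift the number here, if only modestly. The choice between the two aromatic groups makes no readable difference (a 1.6-fold lower number from compound 2 to compound 3 (0.21 log units; within the scatter)), so compound 2 and compound 3 cannot be told apart. Nothing available explains why the step from hexyl to 3-bromophenyl has this size.

On these data alone, it remains open whether the bromine matters at all or the ring alone accounts for the step, a question that plain phenyl would help to settle. Cyclohexyl, a ring that is not aromatic, could likewise show whether a ring of any kind has the same effect at this nitrogen.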